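The source may hold more compounds than are shown below. What is called first, only, known or untested is meant among the compounds shown, and "the series" means these compounds.

Measured compounds:
- compound 1, `CC(=O)Oc1ccccc1C(=O)O[C@H]1CO[C@H]2[C@@H]1OC[C@H]2OC(=O)c1snnc1C`: 0.0065 h
- compound 2, `CC(=O)Oc1ccccc1C(=O)O[C@H]1CO[C@H]2[C@@H]1OC[C@H]2OC(=O)c1ccc(C)cc1`: 0.0362 h
- compound 3, `CC(=O)Oc1ccccc1C(=O)O[C@H]1CO[C@H]2[C@@H]1OC[C@H]2OC(=O)c1ccccc1OC(=O)c1ccccc1`: 0.0722 h

These three compounds share a core carrying two ester groups and were tested in an ADME assay on a cell-free system (plasma, Homo sapiens) for metabolic stability, with Plasma (Rattus norvegicus) as the target, read by HPLC, at pH 7.4; on this read-out lower numbers stand for a shorter-lived compound and higher numbers for a longer-lived compound. Compound 2 sits second highest of the three numbers; its nearest neighbour is compound 3, whose number is within the scatter of it, while compound 1 lies well below it. Within the data shown here, the one single-point step among the measured compounds, a 5.6-fold higher number from compound 1 to compound 2 (0.75 log units; beyond the scatter), shows that exchanging the ring on that carbonyl carbon can move the half-life by a modest but real amount.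

The unmeasured compound 4, `CC(=O)Oc1ccccc1C(=O)O[C@H]1CO[C@H]2[C@@H]1OC[C@H]2OC(=O)c1cnccc1Cl`, differs from compound 2 in exactly that place: 4-chloropyridin-3-yl in place of 4-methylphenyl on a carbonyl carbon. Here a ring of carbon only gives way to a six-membered ring with one hetero atom, recalling that compound 1, the shortest-lived of the three, also carries a ring with hetero atoms on this carbonyl carbon. Among the measured compounds shown here, the step from compound 1 to compound 2 is therefore the only measured step that bears on this change, and it suggests the number may fall again. The expected step is a 2.4-fold lower number from compound 2 to compound 4 (0.38 log units; beyond the scatter), a drop of modest size, though the data give no direct measure of a pyridine ring here. Compound 4 is thus estimated at 0.015 h, with a likely range from 0.005 h to 0.045 h.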

Compound 4, half-life: 0.0322 h
For compound 4 the middle estimate is 2.1-fold (0.33 log units) below the measured one; the range from low to high includes it.
By their numbers in this assay, from the lowest: compound 1; then compounds 4, 2 and 3 (each within the scatter of the next, the first and the last beyond it).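

In this assay the exchange of 4-methylphenyl for 4-chloropyridin-3-yl on this carbonyl carbon gives a 1.1-fold lower number from compound 2 to compound 4 (0.05 log units; within the scatter) and so shows that this place accepts a six-membered ring with a hetero atom and a chlorine with no readable change in half-life. Compound 4 also shows that a ring with a hetero atom here does not in itself go with the short half-life of compound 1, for the exchange of 4-methyl-1,2,3-thiadiazol-5-yl for 4-chloropyridin-3-yl gives a 5.0-fold higher number from compound 1 to compound 4 (0.69 log units; beyond the scatter) and is beyond the scatter. Nothing at hand explains why the 4-methyl-1,2,3-thiadiazol-5-yl ring of compound 1 stands apart from the rings of compound 2 and compound 4.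

The nitrogen and the chlorine enter together in compound 4, so the compounds shown leave open what each does alone, which a plain pyridin-3-yl group or a 4-chlorophenyl group would help to separate. Also open, on these data alone, is how the half-life would read with a group of another kind on this carbonyl carbon, such as a short alkyl chain or a phenyl ring carrying an amine.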